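A few compounds are considered here, and "the series" means these few. Any claim that something is new, unique, unknown or untested is made for them only; others in the source may bear on it.

Measured so far:
- compound 1 `CC(C)(C)c1nc(-c2ccc[nH]2)c2cc(C(N)=O)c(N)nc2n1`: 130000 nM
- compound 2 `CSc1nc(C(C)(C)C)nc2nc(N)c(C#N)c(N)c12`: 14000 nM

In a physicochemical assay for solubility, in phosphate buffer, with a stated time of 18 h (a lower number here means a less soluble compound, a higher number a more soluble compound), compound 2 stands at 14000 nM, the lower of the two numbers. Compound 1, at 130000 nM, lies higher by more than the usual scatter of repeated measurements. Among the compounds with values here, these two compounds differ in more than one place, so they offer no single structural step to learn from.

Compound 3 `Cc1nc(C(C)(C)C)nc2nc(N)c(C#N)c(N)c12` has not yet been measured. It keeps the rest of compound 2 and carries methyl in place of methylsulfanyl on an aromatic carbon, next to the ring nitrogen (methyl in place of methylsulfanyl on an aromatic carbon). Within the data shown here, no measured pair shows this exchange, so the expectation rests on little. A small change is expected in this assay, within the scatter, with a slight lean towards a higher number, and either direction remains possible. The expected size is a 1.6-fold higher number from compound 2 to compound 3 (0.20 log units; within the scatter). The estimate for compound 3 is 22000 nM, with an expected range from 7000 nM to 70000 nM.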

Compound 3, solubility: 37000 nM
Compound 3: the middle estimate sits 1.7-fold (0.23 log units) below what was measured, within the range that was stated.
By their numbers in this assay, from the lowest: compound 2; then compound 3; then compound 1.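

In this assay, within the data shown here, the exchange of methylsulfanyl for methyl on this aromatic carbon, next to the ring nitrogen, gives a 2.6-fold higher number from compound 2 to compound 3 (0.42 log units; beyond the scatter) and so provides the first reading of a single structural change, which the earlier pair of compounds, differing in more than one place, could not offer. By the count of atoms, the exchange removes one sulfur, one carbon and one hydrogen-bond acceptor, and in this one pair the smaller group goes with the higher number, though a single pair cannot establish a trend. No measurement at hand explains the step, so it records a direction and a size but not a cause.

From the compounds shown here alone, this step comes from one pair on one core, so it remains unknown whether the same exchange would give a similar result on the core of compound 1, which differs in more than one place. Going by these compounds, it is also open where other groups on this same carbon would fall relative to methyl and methylsulfanyl, for example an amine, a methoxy group or a longer chain such as ethyl.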